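A few compounds are considered here, and "the series" means these few. Any claim that something is new, unique, unknown or untested is made for them only; others in the source may bear on it.

Three compounds share one core. Compound 1 `Cc1ccccc1OS(=O)(=O)c1cccc(NC(=O)NCCCCl)c1` gives 29000 nM in a functional assay on M21 cells (Homo sapiens) for cytotoxicity, read by sulforhodamine B assay, with a stated time of 48 h; a higher number here means a weaker inhibitor, a lower number a stronger inhibitor; compound 2 `O=C(NCCCCl)Nc1cccc(S(=O)(=O)Oc2ccc(O)cc2)c1` gives 49000 nM, and compound 3 `Cc1ccccc1NS(=O)(=O)c1cccc(NC(=O)NCCCCl)c1` gives 60000 nM, the highest of the three numbers, though a 1.2-fold higher number from compound 2 to compound 3 (0.09 log units; within the scatter) and a 2.1-fold higher number from compound 1 to compound 3 (0.32 log units; beyond the scatter) put only the latter step beyond the scatter. Compound 4 `CCc1ccccc1NS(=O)(=O)c1cccc(NC(=O)NCCCCl)c1` differs from compound 3 by methyl in place of hydrogen on a saturated chain carbon bound to an aromatic carbon, so the 2-methylphenyl becomes a 2-ethylphenyl. For the measured compounds named here, no measured step touches this position: a 1.7-fold higher number from compound 1 to compound 2 (0.23 log units; within the scatter) and the two steps to compound 3 concern the aryl ring and its link to the sulfonyl sulfur, and all were small. Compound 4 is therefore expected to give 60000 nM (range 30000 nM to 120000 nM), a step of no change at the digits printed from compound 3 to compound 4 (within the scatter), not beyond the scatter.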

Compound 4, half-maximal inhibitory concentration: > 200000 nM
Compound 4: a limit, no number; the forecaster's own chance of this, stated with the estimate: 10%; middle value at least 3.3-fold (0.52 log units) away from the limit.
By their numbers in this assay, from the lowest: compounds 1, 2 and 3 (each within the scatter of the next, the first and the last beyond it). At a limit, above all of these: compound 4.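

In this assay compound 4 gives > 200000 nM, which is a limit and not a number. The earlier steps shown here concerned the aryl ring and its link to the sulfonyl sulfur, whereas this one shows that the 2-methylphenyl to 2-ethylphenyl change alone matters, with an at least 3.3-fold higher number from compound 3 to compound 4 (0.52 log units; beyond the scatter). The step is a bound, not a size, and it rests on a single compound: the limit of > 200000 nM in this assay, at which 1 of the 4 values shown sits.

Open, from the compounds shown here alone, is how an amine or a longer chain on this saturated chain carbon would read. Also open, going by these compounds, is whether 2-ethylphenyl would act alike on the oxygen of compound 1.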